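Thiophen-2-yl in place of 4-methylphenyl: compound 4

The source may report more compounds than this note shows. Statements on the series, on what has been measured and on what is new or still open speak of the compounds shown alone.

Compound 3 `CC(=O)OC[C@H]1O[C@@H](n2cc(CN3C(=O)/C(=C\c4ccc(C)cc4)c4ccccc43)nn2)[C@H](OC(C)=O)[C@@H](OC(C)=O)[C@@H]1OC(C)=O` gives 16500 nM in a functional assay on A549 cells (Homo sapiens) for cytotoxicity, read by sulforhodamine B assay, with a stated time of 48 h; on this read-out lower numbers stand for stronger inhibition and higher numbers for weaker inhibition. Compound 2 `CC(=O)OC[C@H]1O[C@@H](n2cc(CN3C(=O)/C(=C/c4ccc(C)cc4)c4ccccc43)nn2)[C@H](OC(C)=O)[C@@H](OC(C)=O)[C@@H]1OC(C)=O` gives 16000 nM in this assay, and the step of a 1.0-fold higher number from compound 2 to compound 3 (0.01 log units; within the scatter) rests on the two compounds differing only in configuration as drawn (the fact that compounds 2 and 3 differ only in the configuration as drawn). Compound 1 `CC(=O)OC[C@H]1O[C@@H](n2cc(Cn3cc(/C=C4/C(=O)Nc5ccccc54)c4ccccc43)nn2)[C@H](OC(C)=O)[C@@H](OC(C)=O)[C@@H]1OC(C)=O` gives only a limit in this assay, > 200000 nM (the limit of > 200000 nM in this assay, at which 1 of the 3 values shown sits). Compound 4 `CC(=O)OC[C@H]1O[C@@H](n2cc(CN3C(=O)/C(=C\c4cccs4)c4ccccc43)nn2)[C@H](OC(C)=O)[C@@H](OC(C)=O)[C@@H]1OC(C)=O` carries thiophen-2-yl in place of 4-methylphenyl on a double-bonded chain carbon bound to a double-bonded ring carbon. Among the measured compounds shown here, no measured step changes the group on that double-bonded chain carbon; the only measured step, between compound 2 and compound 3, is within the scatter, so it offers no direction for this change. No step beyond the scatter is therefore expected in this assay. Compound 4 is expected at 16000 nM, with a range of 6000 nM to 45000 nM, corresponding to an expected step of a 1.0-fold lower number from compound 3 to compound 4 (0.01 log units; within the scatter).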

Compound 4, half-maximal inhibitory concentration: 16100 nM
Compound 4: middle estimate off by 1.0-fold (0.00 log units), on the low side; the measured number falls inside the stated range.
By their numbers in this assay, from the lowest: compounds 2, 4 and 3 (each within the scatter of the next). At a limit, above all of these: compound 1.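

Among the compounds shown here, the step of a 1.0-fold lower number from compound 3 to compound 4 (0.01 log units; within the scatter) in this assay is the only measured change of the group on this double-bonded chain carbon. On this evidence, a five-membered aromatic ring with a sulfur atom can replace 4-methylphenyl at this position without a step beyond the scatter. Nothing measured here gives a cause for this result.

Going by these compounds, whether a carboxylic acid, an amine or a longer chain in place of thiophen-2-yl at this carbon would shift the number remains open. Also open, on these data alone, is whether thiophen-2-yl gives a similar number in the opposite double-bond configuration.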